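A few compounds are considered here, and "the series" means these few. Any claim that something is new, unique, unknown or untested is made for them only; others in the source may bear on it.

Of the compounds shown here, two sharing one core have been read so far in a functional assay on SGC-7901 cells (Homo sapiens) for antiproliferative activity, read by MTT assay, with a stated time of 72 h; a lower number here means a stronger inhibitor, a higher number a weaker inhibitor. Compound 1 (`COc1cc(-c2cc(C(=O)O)sc2-c2cccc(Br)c2)cc(OC)c1OC`) gives 93400 nM, and compound 2 (`COc1ccc(-c2sc(C(=O)O)cc2-c2cc(OC)c(OC)c(OC)c2)cc1[N+](=O)[O-]`) gives 23300 nM. Compound 2 therefore holds the lower number of the pair, and its gap to compound 1 lies beyond the scatter. The next structure, compound 3 (`COc1ccc(-c2sc(C(=O)O)cc2-c2cc(OC)c(OC)c(OC)c2)cc1O`), carries hydroxy in place of nitro on an aromatic carbon, ortho to a methoxy group: hydroxy in place of nitro on an aromatic carbon. Among the measured compounds shown here, no measured step isolates this change, so the expectation is a loose one. In this assay, a small step toward a lower number is expected, lying near the edge of the scatter. The estimated change is a 1.9-fold lower number from compound 2 to compound 3 (0.29 log units; within the scatter). For compound 3 the estimated value is 12000 nM, with an expected range of 2500 nM to 50000 nM.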

Compound 3, half-maximal inhibitory concentration: 6100 nM
Compound 3: middle estimate off by 2.0-fold (0.29 log units), on the high side, and the stated range covers the measured number.
By their numbers in this assay, from the lowest: compound 3; then compound 2; then compound 1.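

In this assay, hydroxy in place of nitro on an aromatic carbon, ortho to a methoxy group, gives a 3.8-fold lower number from compound 2 to compound 3 (0.58 log units; beyond the scatter), so this one position alone moves the number beyond the scatter. The wider swap of 3-hydroxy-4-methoxyphenyl in place of 3-bromophenyl gives a 15-fold lower number from compound 1 to compound 3 (1.19 log units; beyond the scatter), which leaves compound 3 with the lowest number of the three at 6100 nM. Nothing at hand explains either step.

Going by these compounds, it remains open whether hydroxy is specifically favoured on this carbon, or whether an amine or a fluorine there would give a similar number. Also open, on these data alone, is whether the carboxylic acid on the shared core can be replaced by a methyl ester or an amide without losing the gain seen with compound 3.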